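The compounds below may be only part of what the source reports. "The series", "measured", "known", "first", "only" and "open" are said of these compounds alone.

Three compounds that share one core and differ only in the group on an aromatic carbon of that core have been measured in a functional assay on SK-OV-3 cells (Homo sapiens) for cytotoxicity; a higher number here means a weaker inhibitor, a lower number a stronger inhibitor. Compound 1 (`Cc1nn(C)c(-n2ccc3ccccc32)c1/C=N/OCc1ccc(C(=O)OC(C)(C)C)cc1`), which carries 1H-indol-1-yl, gives 2.07 ug/mL. Compound 2 (`Cc1nn(C)c(N2CCCC2)c1/C=N/OCc1ccc(C(=O)OC(C)(C)C)cc1`), which carries pyrrolidin-1-yl, gives 3.19 ug/mL. Compound 3 (`Cc1nn(C)c(-n2ccnc2)c1/C=N/OCc1ccc(C(=O)OC(C)(C)C)cc1`), which carries 1H-imidazol-1-yl, gives 14.1 ug/mL, the highest number of the three and the weakest result, beyond the scatter of both others.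

Compound 4 (`Cc1nn(C)c(Sc2ccccc2)c1/C=N/OCc1ccc(C(=O)OC(C)(C)C)cc1`) has phenylsulfanyl in place of 1H-imidazol-1-yl on an aromatic carbon. For the measured compounds named here, no measured compound carries phenylsulfanyl, so the evidence is indirect. Going by the values given here, the steps that bear on this change are those that remove or introduce 1H-imidazol-1-yl, namely a 6.8-fold higher number from compound 1 to compound 3 (0.83 log units; beyond the scatter) and a 4.4-fold higher number from compound 2 to compound 3 (0.65 log units; beyond the scatter). By contrast, a 1.5-fold higher number from compound 1 to compound 2 (0.19 log units; within the scatter) shows no separation between the two groups other than 1H-imidazol-1-yl. Leaving 1H-imidazol-1-yl is therefore expected to give a modest move to a lower number in this assay, of about the size of those two steps. The estimated step is a 4.0-fold lower number from compound 3 to compound 4 (0.61 log units; beyond the scatter). For compound 4 the expected value is 3.5 ug/mL, with an estimated range from 1.4 ug/mL to 9 ug/mL.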

Compound 4, half-maximal inhibitory concentration: 0.92 ug/mL
Estimate against measurement, compound 4: 3.8-fold (0.58 log units) above, outside the stated range (below it).
By their numbers in this assay, from the lowest: compound 4; then compounds 1 and 2 (each within the scatter of the next); then compound 3.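

In this assay, for the compounds shown here, the earlier compounds left open whether this position simply had one poor group, 1H-imidazol-1-yl, with the other two groups within the scatter of each other. Phenylsulfanyl shows that more can be gained here than by leaving 1H-imidazol-1-yl alone: the change gives a 15-fold lower number from compound 3 to compound 4 (1.19 log units; beyond the scatter), and it also moves beyond both of the better earlier groups, with a 3.5-fold lower number from compound 2 to compound 4 (0.54 log units; beyond the scatter) and a 2.3-fold lower number from compound 1 to compound 4 (0.35 log units; beyond the scatter), which makes compound 4 the most potent of the four in this cell assay. The group placed on this aromatic carbon therefore still sets the number even among groups that had looked equivalent, though nothing in the data shown explains why phenylsulfanyl behaves this way.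

The compounds shown leave open whether the sulfur or the phenyl ring carries the step, a question that a phenoxy group or a methylsulfanyl group at the same position would help to separate. Also open, on these data alone, is how far these differences depend on the tert-butyl ester that all four compounds share, which a free carboxylic acid in its place would test.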